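Removing a Fluorine from a Sulfonamide Aryl Ring

The compounds below may be only part of what the source reports. "The series", "measured", "known", "first", "only" and "open" are said of these compounds alone.

Compound 1 `Cc1ccc(F)cc1S(=O)(=O)N1CCN(c2ccc(C(=O)NCc3ccc(F)cc3)nn2)CC1`: 1.13 h
Compound 2 `O=C(NCc1ccccc1)c1ccc(N2CCN(S(=O)(=O)c3ccccc3Cl)CC2)nn1`: 0.0333 h
Compound 3 `Cc1ccccc1S(=O)(=O)N1CC=C(c2ccc(C(=O)NCc3ccc(F)cc3)nn2)CC1`: 0.0833 h

In an ADME assay on microsomes from liver (Mus musculus) for metabolic stability, read by LC-MS, using NADPH, tested at 10 uM (a higher number here means that the compound lasts longer, a lower number that the compound disappears faster), compound 1 gives 1.13 h and stands highest of the three measured compounds. Its nearest neighbour is compound 3, with 0.0833 h, and furthest is compound 2, with 0.0333 h; both gaps to compound 1 lie beyond the scatter of the assay. Compound 4 `Cc1ccccc1S(=O)(=O)N1CCN(c2ccc(C(=O)NCc3ccc(F)cc3)nn2)CC1` has not yet been measured in this assay. It differs from compound 1 in one place: hydrogen in place of fluoro on an aromatic carbon. Within the data shown here, no step between two measured compounds isolates this change, so there is no directly comparable precedent. Compound 3 carries the same 2-methylphenyl sulfonyl group as compound 4, though on a different core, and its value sits well under that of compound 1. On that basis a moderate fall is expected, a 2.8-fold lower number from compound 1 to compound 4 (0.45 log units; beyond the scatter), larger than the scatter but short of the gap to compound 3. Compound 4 is therefore estimated at 0.4 h, within a range from 0.1 h to 1.2 h.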

Compound 4, half-life: 0.433 h
Compound 4: the middle estimate sits 1.1-fold (0.03 log units) below what was measured; the range from low to high includes it.
By their numbers in this assay, from the lowest: compound 2; then compound 3; then compound 4; then compound 1.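

In this assay, among these compounds, putting hydrogen in place of the fluoro on the 5-fluoro-2-methylphenyl group gives a 2.6-fold lower number from compound 1 to compound 4 (0.42 log units; beyond the scatter) and is the first step here to isolate this one position, on an aromatic carbon meta to a large group and para to a methyl group. This single-atom swap moves the half-life beyond the usual scatter, so this fluoro is tied to a real, though modest, difference between two otherwise identical compounds. Nothing measured here explains why the half-life shifts with this change.

The compounds shown leave open how a methoxy group or a nitrile at this same place would compare with fluoro and hydrogen. They also leave open whether the same swap would give a step of similar size on a different core.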